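The source may hold more compounds than are shown below. What is called first, only, known or untested is meant among the compounds shown, and "the series" means these compounds.

Measured compounds in a functional assay on MT4 cells (Homo sapiens); on this read-out lower numbers stand for higher toxicity in this test and higher numbers for lower toxicity in this test:

compound 1, `COC(=O)CNC1=CS(=O)(=O)O[C@@]12[C@@H](CO[Si](C)(C)C(C)(C)C)O[C@@H](n1cc(C)c(=O)n(C)c1=O)[C@@H]2O[Si](C)(C)C(C)(C)C`: 105000 nM
compound 2, `C=C(C)C(=O)NC(=O)NC1=CS(=O)(=O)O[C@@]12[C@@H](CO[Si](C)(C)C(C)(C)C)O[C@@H](n1cc(C)c(=O)n(C)c1=O)[C@@H]2O[Si](C)(C)C(C)(C)C`: 1190 nM
compound 3, `Cc1cn([C@@H]2O[C@H](CO[Si](C)(C)C(C)(C)C)[C@@]3(OS(=O)(=O)C=C3NC(=O)NC(=O)c3ccccc3)[C@H]2O[Si](C)(C)C(C)(C)C)c(=O)n(C)c1=O`: 3330 nM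

Compound 3 stands second highest of the three numbers in this assay. Its nearest neighbour is compound 2, with a 2.8-fold higher number from compound 2 to compound 3 (0.45 log units; beyond the scatter) between them, and its furthest is compound 1, from which a 32-fold lower number from compound 1 to compound 3 (1.50 log units; beyond the scatter) leads.

Compound 4 is `Cc1cn([C@@H]2O[C@H](CO[Si](C)(C)C(C)(C)C)[C@@]3(OS(=O)(=O)C=C3NCC(=O)C(=O)O)[C@H]2O[Si](C)(C)C(C)(C)C)c(=O)n(C)c1=O` and has not yet been measured. It differs from compound 3 in one place: (carboxycarbonyl)methyl in place of benzoylcarbamoyl on an amine nitrogen.

Within the data shown here, the steps that bear on this change are those that swap a small chain on the amine nitrogen for an acyl carbamoyl group: an 88-fold lower number from compound 1 to compound 2 (1.95 log units; beyond the scatter) and a 32-fold lower number from compound 1 to compound 3 (1.50 log units; beyond the scatter). Both were large and ran in the direction of lower numbers. Compound 4 goes the other way, back toward a short chain on that nitrogen, so a large step toward higher numbers is expected, roughly reversing the step from compound 1 to compound 3. Among the measured compounds shown here, no measured compound carries a carboxyl group, so the estimate is wide. Compound 4 is therefore expected at about 50000 nM, within 10000 nM to 150000 nM, meaning an expected step of a 15-fold higher number from compound 3 to compound 4 (1.18 log units; beyond the scatter).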

Compound 4, half-maximal cytotoxic concentration: 31100 nM
Estimate against measurement, compound 4: 1.6-fold (0.21 log units) above; the measured number falls inside the stated range.
By their numbers in this assay, from the lowest: compound 2; then compound 3; then compound 4; then compound 1.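

In this assay, replacing the acyl carbamoyl group on the amine nitrogen with a short chain largely reverses the earlier drop: a 9.3-fold higher number from compound 3 to compound 4 (0.97 log units; beyond the scatter) and a 26-fold higher number from compound 2 to compound 4 (1.42 log units; beyond the scatter). Across these four compounds, the two lowest numbers belong to the acyl carbamoyl compounds and the two highest to the short-chain compounds, and no compound goes against this. The end of the short chain also counts: a 3.4-fold lower number from compound 1 to compound 4 (0.53 log units; beyond the scatter), with carboxy in place of methoxy on a carbonyl carbon.

Nothing available explains any of these shifts. Still open, as far as these compounds go, is how the number would respond to a short chain ending in an amine, or to a longer chain ending in a carboxylic acid, on this same nitrogen.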